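The source may hold more compounds than are shown below. What is called first, only, known or untested is meant among the compounds shown, and "the series" means these compounds.

Measured compounds:
compound 1 `O=C(CI)NCCCCC(=O)NCCCCCCNc1ncnc2c1ncn2[C@@H]1O[C@H](COP(=O)(O)OP(=O)(O)OP(=O)(O)O)[C@@H](O)[C@H]1O`, which in an assay on isolated protein for inhibition of hexokinase-3 (Rattus norvegicus), with a stated time of 6 h, tested at 10 mM (on this read-out higher numbers stand for more inhibition at the one concentration tested (going by the name of the read-out) and lower numbers for less inhibition), gives 0%;
compound 2 `CN(CCCN(C)C(=O)CCCNc1ncnc2c1ncn2[C@@H]1O[C@H](COP(=O)(O)OP(=O)(O)OP(=O)(O)O)[C@@H](O)[C@H]1O)C(=O)CCCNC(=O)CI`, which gives 0%;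
compound 3 `CN(CCCCN(C)C(=O)CCCCNc1ncnc2c1ncn2[C@@H]1O[C@H](COP(=O)(O)OP(=O)(O)OP(=O)(O)O)[C@@H](O)[C@H]1O)C(=O)CCCCNC(=O)CI`, which gives 0%.

Compound 1 stands level with compounds 2 and 3 in this assay: all three return the same reading at the digits given, and neither the nearest comparison, compound 2, nor the furthest, compound 3, differs from compound 1 beyond the scatter. Compound 4 `O=C(I)NCC(=O)NCCCCCCNc1ncnc2c1ncn2[C@@H]1O[C@H](COP(=O)(O)OP(=O)(O)OP(=O)(O)O)[C@@H](O)[C@H]1O` arises from compound 1 by one change, (a group of 4 heavy atoms (1 carbon, 1 nitrogen, 1 oxygen, 1 iodine; no ring) in place of a group of 8 heavy atoms (5 carbon, 1 nitrogen, 1 oxygen, 1 iodine; no ring), on a saturated chain carbon bound to a carbonyl carbon). Among the compounds with values here, no step between measured compounds that differ in a single place is available, so the expectation rests on the three equal readings alone. The step from compound 1 to compound 4 is expected to be no change at the digits printed from compound 1 to compound 4 (within the scatter), none beyond the scatter. Compound 4 is therefore estimated to give 0% in this assay, with a range from -8% to 10%.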

Compound 4, a percentage reported as inhibition, at one concentration (the size of the read-out at that concentration, not a potency): 0%
Compound 4: middle estimate and measured number agree at the digits printed, and the stated range covers the measured number.
By their numbers in this assay, from the lowest: compounds 1, 2, 3 and 4 (each within the scatter of the next).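

Within the data shown here, at this position, on a saturated chain carbon bound to a carbonyl carbon, this assay gives the first step that can be read in a single place: no change at the digits printed from compound 1 to compound 4 (within the scatter). Replacing the 3-(((iodomethyl)carbonyl)amino)propyl group of 8 heavy atoms with a group of 4 heavy atoms therefore leaves the reading unmoved, and inhibition remains absent at both sizes. Nothing available explains this equality. From the compounds shown here alone, whether a different group at this place, such as a carboxylic acid or an amine, would give any measurable inhibition remains open.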